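Chloro for amino on the benzyl ring of compound 3

The source may hold more compounds than are shown below. What is called first, only, known or untested is meant among the compounds shown, and "the series" means these compounds.

Compound 1: `NC(=O)c1cccc(Cn2cc(-c3ccc4cn[nH]c4c3)ccc2=O)c1`, 388 nM in an assay for inhibition of MAP kinase-interacting serine/threonine-protein kinase 1 (Homo sapiens), read by luminescence and ADP-Glo, with a stated time of 2 h; a higher number here means a weaker inhibitor, a lower number a stronger inhibitor
Compound 2: `O=c1ccc(-c2ccc3cn[nH]c3c2)cn1Cc1cccc(C(F)(F)F)c1`, 40 nM
Compound 3: `Nc1cccc(Cn2cc(-c3ccc4cn[nH]c4c3)ccc2=O)c1`, 287 nM

Compound 3 gives the second highest number of the three in this assay; compound 1 is nearest, with a 1.4-fold lower number from compound 1 to compound 3 (0.13 log units; within the scatter), and compound 2 is furthest, with a 7.2-fold higher number from compound 2 to compound 3 (0.86 log units; beyond the scatter). Compound 4, `O=c1ccc(-c2ccc3cn[nH]c3c2)cn1Cc1cccc(Cl)c1`, differs from compound 3 in one place: chloro in place of amino on an aromatic carbon. Within the data shown here, no measured step exchanges amino for chloro directly. The step that bears on it most closely is a 7.2-fold higher number from compound 2 to compound 3 (0.86 log units; beyond the scatter), since it also removes the amino group at this position in favour of a group carrying no hydrogen-bond donor or acceptor. The step of a 9.7-fold lower number from compound 1 to compound 2 (0.99 log units; beyond the scatter) shows the same position accepting a large shift when carbamoyl leaves. On this basis compound 4 is expected to give a lower number than compound 3 in this assay, with a step estimated as a 3.8-fold lower number from compound 3 to compound 4 (0.58 log units; beyond the scatter). Compound 4 is estimated at 75 nM, within a range of 25 nM to 220 nM.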

Compound 4, half-maximal inhibitory concentration: 37 nM
Compound 4: the middle estimate sits 2.0-fold (0.31 log units) above what was measured; measured number inside the range.
By their numbers in this assay, from the lowest: compounds 4 and 2 (each within the scatter of the next); then compounds 3 and 1 (each within the scatter of the next).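

In this assay, chloro gives a 7.8-fold lower number from compound 3 to compound 4 (0.89 log units; beyond the scatter) and, set against carbamoyl, a 10-fold lower number from compound 1 to compound 4 (1.02 log units; beyond the scatter), so this place on the aromatic ring now has a second group that separates clearly from both amino and carbamoyl. Chloro and trifluoromethyl, by contrast, are not separated, with a 1.1-fold lower number from compound 2 to compound 4 (0.03 log units; within the scatter), which shows that the smaller chloro group matches trifluoromethyl here and that the larger group is not needed for the lower number. Nothing measured here explains why the numbers fall in this way.

The compounds shown leave open whether a methyl, bromo or methoxy group at this place would stay level with compound 2 and compound 4. They also leave open whether chloro would give a similar number on another carbon of the same ring.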